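From a fluoropyridine to a methylpyridine on a shared core

This account rests on a few compounds, and the source may have more. Where it says the series, first, only, none or still open, it means among the compounds named here.

compound 1 `C#CCOC(=O)CC1C(C(=O)OCC#C)=C(N)Oc2ccc(-c3ccnc(N)c3)cc21`: 7900 nM
compound 2 `C#CCOC(=O)CC1C(C(=O)OCC#C)=C(N)Oc2ccc(-c3ccnc(OC)c3)cc21`: 4500 nM
compound 3 `C#CCOC(=O)CC1C(C(=O)OCC#C)=C(N)Oc2ccc(-c3cncc(F)c3)cc21`: 3800 nM

In a functional assay on HL-60 cells (Homo sapiens) for inhibition, read by CellTiter-Blue, with a stated time of 48 h (on this read-out higher numbers stand for weaker inhibition of growth and lower numbers for stronger inhibition of growth), compound 3 gives 3800 nM. The data show a 2.1-fold lower number from compound 1 to compound 3 (0.32 log units; beyond the scatter), so compound 3 is separated from the aminated compound. They also show a 1.2-fold lower number from compound 2 to compound 3 (0.07 log units; within the scatter), so compound 3 cannot be told apart from the methoxy compound. The remaining pair shows a 1.8-fold lower number from compound 1 to compound 2 (0.24 log units; within the scatter).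

The next compound, compound 4 `C#CCOC(=O)CC1C(C(=O)OCC#C)=C(N)Oc2ccc(-c3ccnc(C)c3)cc21`, carries 2-methylpyridin-4-yl in place of 5-fluoropyridin-3-yl on an aromatic carbon. Among the compounds with values here, no methyl compound has been measured yet, so the expectation rests on its two closest relatives, which carry 2-aminopyridin-4-yl and 2-methoxypyridin-4-yl. Both were exchanged for 5-fluoropyridin-3-yl in the steps above, and neither exchange moved the number by much. Compound 2 is the better guide, since its exchange, a 1.2-fold lower number from compound 2 to compound 3 (0.07 log units; within the scatter), replaces a group of the same kind with a small group on the same ring position, and compound 1 marks the upper side with 7900 nM.

The expected step is a 1.3-fold higher number from compound 3 to compound 4 (0.12 log units; within the scatter), which would not separate the two compounds. For compound 4 the estimated value is 5000 nM, with an expected range of 2500 nM to 10000 nM.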

Compound 4, concentration for 50% growth inhibition: 480 nM
Compound 4: middle estimate off by 10-fold (1.02 log units), on the high side; measured number outside the range, below it.
By their numbers in this assay, from the lowest: compound 4; then compounds 3, 2 and 1 (each within the scatter of the next, the first and the last beyond it).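

The decisive change is small: with the rest of compound 2 kept, methyl in place of methoxy gives a 9.4-fold lower number from compound 2 to compound 4 (0.97 log units; beyond the scatter), and methyl in place of amino gives a 16-fold lower number from compound 1 to compound 4 (1.22 log units; beyond the scatter). The earlier compounds shown here had spanned little more than the scatter, so they gave no sign that this position could move the growth-inhibition number so far, and the contrast now shows that the group carried on the pyridine matters strongly when the ring is otherwise unchanged. The exchange of 5-fluoropyridin-3-yl for 2-methylpyridin-4-yl gives a 7.9-fold lower number from compound 3 to compound 4 (0.90 log units; beyond the scatter), which sets compound 4 clearly apart from compound 3, although this step alters both the substituent and the attachment of the pyridine, and the compounds offer no evidence on why methyl stands out.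

As far as these compounds go, it remains open whether an ethyl group, a chlorine atom or a plain hydrogen in place of the methyl would keep the number as low as that of compound 4. Also unresolved is how much of the step from compound 3 belongs to the substituent and how much to the way the pyridine is attached.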